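Swapping Methoxy for Bromo on a Second Ring

The source may hold more compounds than are shown below. What is called first, only, known or untested is meant among the compounds shown, and "the series" means these compounds.

Of the compounds shown here, three have been measured in an assay for inhibition of transmembrane protease serine 4 (Homo sapiens), read by fluorescence; on this read-out lower numbers stand for stronger inhibition and higher numbers for weaker inhibition. Compound 1 `O=C(Nc1cc(C(F)(F)F)cc(C(F)(F)F)c1)c1cc(Br)ccc1O` gives 13000 nM. Compound 2 `COc1ccc(O)c(C(=O)Nc2cc(C(F)(F)F)cc(C(F)(F)F)c2)c1` gives 29000 nM in this assay. Compound 3 `COc1cc(NC(=O)c2cc(Cl)ccc2O)cc(C(F)(F)F)c1` gives 16000 nM. Compound 4 `O=C(Nc1cc(Br)cc(C(F)(F)F)c1)c1cc(Cl)ccc1O` has not yet been measured.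

Compound 1 arises from compound 2 by the change (bromo in place of methoxy on an aromatic carbon), and that step was a 2.2-fold lower number from compound 2 to compound 1 (0.35 log units; beyond the scatter). Compound 4 arises from compound 3 by bromo in place of methoxy on an aromatic carbon, the same kind of change, though the surroundings differ: in the earlier pair the site is para to a hydroxy group, whereas in the new pair it is meta to a trifluoromethyl group. How the core of compound 2 differs from the core of compound 3 is not broken down here. Compound 3 and compound 1 lie within the scatter of each other, as do compound 3 and compound 2.

For compound 4 a step of a 1.8-fold lower number from compound 3 to compound 4 (0.25 log units; within the scatter) is expected in this assay. Within the data shown here, that expectation rests on the single earlier step of a 2.2-fold lower number from compound 2 to compound 1 (0.35 log units; beyond the scatter) and on compound 3 at 16000 nM. The surroundings of the change are not identical in the two pairs, so the range is left wide. Compound 4 is therefore estimated at 9000 nM, within a range from 4000 nM to 20000 nM.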

Compound 4, half-maximal inhibitory concentration: 12000 nM
For compound 4 the middle estimate is 1.3-fold (0.12 log units) below the measured one; the measured number falls inside the stated range.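

In this assay the swap of methoxy for bromo on the core of compound 3 gave a 1.3-fold lower number from compound 3 to compound 4 (0.12 log units; within the scatter) and so, taken alone, shows no clear change. Set beside the earlier pair, the two steps cannot be told apart: the same change on two cores in this assay, a 2.2-fold lower number (0.35 log units; beyond the scatter) from compound 2 to compound 1 and a 1.3-fold lower number (0.12 log units; within the scatter) from compound 3 to compound 4, 1.7-fold (0.22 log units) apart, within the scatter of two such steps. Among these compounds, the two cores thus agree with a single small effect of the swap, but two pairs do not show that the step keeps its size on other cores, and the newer step on its own cannot be told from no step at all.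

The compounds shown leave open how the series responds when the site that carries methoxy or bromo holds another group, such as a nitrile, an amine or a longer alkyl chain. Also open, on these data alone, is whether the same swap would read alike on a core with a carboxylic acid in place of the hydroxy group.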